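Cyclobutylcarbonyl Replaces Isobutyl on a Ring Amine Nitrogen

The source may report more compounds than this note shows. Statements on the series, on what has been measured and on what is new or still open speak of the compounds shown alone.

Of the compounds shown here, three sharing one core have been tested in an assay on HEK293 cells for negative allosteric modulation of metabotropic glutamate receptor 5 (Homo sapiens), read by FLIPR, with a stated time of 1 h; a higher number here means a weaker inhibitor, a lower number a stronger inhibitor. Compound 1 `Cc1cccc(C#Cc2nc3c(s2)C(=O)NCC3)c1` gives only a limit of this assay, > 10000 nM. Compound 2 `O=C1c2sc(C#Cc3ccccc3)nc2CN1C1CC1` gives 23 nM in this assay. Compound 3 `CC(C)CN1CCc2nc(C#Cc3ccccc3)sc2C1` gives 650 nM, the higher of the two numbers reported, and its distance from compound 2 lies beyond the scatter. Compound 4 `O=C(C1CCC1)N1CCc2nc(C#Cc3ccccc3)sc2C1` has not yet been measured in this assay. It differs from compound 3 in one place: cyclobutylcarbonyl in place of isobutyl on an amine nitrogen in a ring. Going by the values given here, no measured pair isolates this change. Compound 2 also carries a carbonyl group and gives 23 nM. A clear drop in the number is therefore expected, as an 8.1-fold lower number from compound 3 to compound 4 (0.91 log units; beyond the scatter). For compound 4 the expected value is 80 nM, within a range from 20 nM to 320 nM.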

Compound 4, half-maximal inhibitory concentration: 370 nM
The estimate for compound 4 lay 4.6-fold (0.67 log units) below the measured number; the measured number lies above the stated range.
By their numbers in this assay, from the lowest: compound 2; then compounds 4 and 3 (each within the scatter of the next). At a limit, above all of these: compound 1.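

Replacing isobutyl with cyclobutylcarbonyl on the amine nitrogen in the ring gives a 1.8-fold lower number from compound 3 to compound 4 (0.24 log units; within the scatter) in this assay, so in this pair the two groups read alike. Adding a carbonyl, and with it a hydrogen-bond acceptor, therefore brings no gain beyond the scatter at this position. Nothing measured here bears on why the two groups read alike.

On these data alone, it remains open how a simple acetyl group, a sulfonamide or a longer chain ending in a carboxylic acid would read on this nitrogen.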